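Chloro to Methyl on the Aryl Ester of a Shared Core

The compounds below may be only part of what the source reports. "The series", "measured", "known", "first", "only" and "open" are said of these compounds alone.

Measured compounds:
compound 1, `CC1=CC[C@H](C(C)C)c2cc(C)c(OC(=O)Nc3ccccc3)cc21`: 75.1%
compound 2, `CC1=CC[C@H](C(C)C)c2cc(C)c(OC(=O)c3cccc(Cl)c3)cc21`: 40.4%

In a functional assay on MCF7 cells (Homo sapiens) for antiproliferative activity, read by sulforhodamine B assay, with a stated time of 48 h, tested at 50 uM (a lower number here means less inhibition, a higher number more inhibition at the concentration tested (going by the name of the read-out)), compound 2 stands lowest of the two numbers, since the change a number 34.7 percentage points lower from compound 1 to compound 2 (beyond the scatter) carried the signal well beyond the scatter. Compound 3, `CC1=CC[C@H](C(C)C)c2cc(C)c(OC(=O)c3cccc(C)c3)cc21`, differs from compound 2 by methyl in place of chloro on an aromatic carbon. For the measured compounds named here, no measured step concerns this kind of swap; the only step known changes the group on the carbonyl carbon instead, so it gives no direct guide. With nothing pointing either way, the step of a number 0.4 percentage points lower from compound 2 to compound 3 (within the scatter) is expected to stay within the scatter. Compound 3 is therefore estimated at 40%, with a range from 20% to 60%.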

Compound 3, a percentage reported as inhibition, at one concentration (the size of the read-out at that concentration, not a potency): 54.9%
Estimate against measurement, compound 3: 14.9 percentage points below; the measured number falls inside the stated range.
By their numbers in this assay, from the lowest: compound 2; then compound 3; then compound 1.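

Replacing chloro with methyl on this aromatic carbon, meta to a large group, gives a number 14.5 percentage points higher from compound 2 to compound 3 (beyond the scatter) and so shows that this single-atom exchange can move the inhibition measurably. The methyl compound still trails the anilino carbamate, with a number 20.2 percentage points lower from compound 1 to compound 3 (beyond the scatter) as the step. Nothing available explains either step. From the compounds shown here alone, whether a methoxy group, an amine or a longer chain at this place would raise the inhibition further stays open. So does how methyl would behave on the ring at other positions.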